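Methoxy on the Phenyl of Compound 2: An Estimate

A few compounds are considered here, and "the series" means these few. Any claim that something is new, unique, unknown or untested is made for them only; others in the source may bear on it.

Compound 1 `O=c1cc(-c2ccccc2)oc2ccc(OC/C(=N/O)c3ccccc3)cc12`: 700000 nM
Compound 2 `CO/N=C(/COc1ccc2oc(-c3ccccc3)cc(=O)c2c1)c1ccccc1`: 8200000 nM

In a functional assay on SK-HEP1 cells (Homo sapiens) for antiproliferative activity (a lower number here means a stronger inhibitor of growth, a higher number a weaker inhibitor of growth), compound 1 gives 700000 nM, and in the same test compound 2 gives 8200000 nM. Compound 2 thus stands at the higher of the two numbers; the step of a 12-fold higher number from compound 1 to compound 2 (1.07 log units; beyond the scatter) separates it from compound 1. Compound 3 `CO/N=C(/COc1ccc2oc(-c3ccccc3)cc(=O)c2c1)c1ccc(OC)cc1` differs from compound 2 by methoxy in place of hydrogen on an aromatic carbon. Going by the values given here, no measured step bears on this change: the single known step concerns a methyl added on an oxygen, not a methoxy on the phenyl, and it offers no guide to either direction or size. With nothing comparable to lean on, the step of a 1.0-fold lower number from compound 2 to compound 3 (0.01 log units; within the scatter) is expected to stay within the scatter. Compound 3 is therefore estimated at 8000000 nM, with a range from 2000000 nM to 30000000 nM, and a number this high carries a real chance of being reported only as a limit.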

Compound 3, concentration for 50% growth inhibition: 2000000 nM
The estimate for compound 3 lay 4.0-fold (0.60 log units) above the measured number, and the stated range covers the measured number.
By their numbers in this assay, from the lowest: compound 1; then compound 3; then compound 2.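

In this assay, the change from phenyl to 4-methoxyphenyl gives a 4.1-fold lower number from compound 2 to compound 3 (0.61 log units; beyond the scatter). This shows that the aromatic carbon para to a large group is not a silent position: adding methoxy there moves the number beyond the scatter. Going by these compounds alone, the direction is towards stronger growth inhibition, opposite to that of the only earlier step, the methyl on an oxygen, which gave a 12-fold higher number from compound 1 to compound 2 (1.07 log units; beyond the scatter). No available evidence accounts for this gain.

As far as these compounds go, it remains open whether the shift belongs to methoxy itself, and how a fluorine, an amine or a carboxylic acid on the same carbon, or a longer chain such as ethoxy, would compare. Also open, from the compounds shown here alone, is whether methoxy at this position would have the same effect on compound 1, with hydrogen still on its oxygen.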